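This account rests on a few compounds, and the source may have more. Where it says the series, first, only, none or still open, it means among the compounds named here.

Of the compounds shown here, two have been measured in a functional assay on A549 cells (Homo sapiens) for cytotoxicity, read by MTT assay, with a stated time of 72 h; a lower number here means a stronger inhibitor, a higher number a weaker inhibitor. Compound 1, `COc1c(OCCCCN2CCN(C)CC2)cc(O)c2c(=O)cc(-c3ccc([N+](=O)[O-])cc3)oc12`, gives 3210 nM. Compound 2, `O=c1cc(-c2ccccc2)oc2c(OCCCN3CCCC3)c(OCc3ccccc3)cc(O)c12`, gives 4720 nM. Of the two numbers, that of compound 2 is the higher, but its gap to compound 1 lies within the scatter, so the two cannot be told apart on these data alone.

Compound 3, `CN(C)CCCCOc1c(OCc2ccccc2)cc(O)c2c(=O)cc(-c3ccccc3)oc12`, has not yet been measured. It differs from compound 2 in one place: (dimethylamino)methyl in place of pyrrolidin-1-yl on a saturated chain carbon, three bonds along the chain from an oxygen on an aromatic ring. Going by the values given here, both groups are tertiary amines at the end of the same chain, and nothing among the measured compounds shows how this assay responds to such a swap. Among the compounds with values here, with no measured step to lean on, the expected change in this assay is none beyond the scatter, and the estimated step is a 1.0-fold lower number from compound 2 to compound 3 (0.02 log units; within the scatter). Compound 3 is therefore expected to give about 4500 nM, with a range from 2000 nM to 10000 nM.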

Compound 3, half-maximal inhibitory concentration: 1090 nM
Beside the measured number, compound 3's estimate is 4.1-fold (0.62 log units) above it; the measured number lies below the stated range.
By their numbers in this assay, from the lowest: compound 3; then compounds 1 and 2 (each within the scatter of the next).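

Going from a 3-(pyrrolidin-1-yl)propyl group to a 4-(dimethylamino)butyl group gives a 4.3-fold lower number from compound 2 to compound 3 (0.64 log units; beyond the scatter) in this assay and so shows, as no earlier pair could, that this assay responds to a change at the end of this chain. Read that way, the step holds two changes at once: the five-membered ring gives way to an open dimethylamino group, and the chain goes from propyl to butyl. No measurement shown here explains the size of this step.

The compounds shown therefore leave open how much of the step belongs to the amine and how much to the chain. A 3-(dimethylamino)propyl group or a pyrrolidine on the butyl chain would separate the two, and a longer chain would show whether the trend continues.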